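A bulkier amide aryl on a weak benzyl analogue

The compounds below may be only part of what the source reports. "The series", "measured", "known", "first", "only" and "open" are said of these compounds alone.

Compound 1 `Cc1cccc(Cl)c1NC(=O)CN1CCN(c2nnc(Cc3ccncc3)c3ccccc23)CC1` gives 22600 nM in a functional assay on HT-29 cells (Homo sapiens) for cytotoxicity, read by MTT assay, with a stated time of 72 h; on this read-out lower numbers stand for stronger inhibition and higher numbers for weaker inhibition.
Compound 2 `Cc1ccc(F)cc1NC(=O)CN1CCN(c2nnc(Cc3ccccc3)c3ccccc23)CC1` gives 171000 nM in this assay.
Compound 3 `Cc1ccc(F)cc1NC(=O)CN1CCN(c2nnc(Cc3ccncc3)c3ccccc23)CC1` gives 470 nM in this assay.

Compound 2 stands at the highest number of the three, that is, it is the weakest inhibitor measured here. Compound 1 is its nearest neighbour, and compound 3 lies furthest away, as the step of a 360-fold lower number from compound 2 to compound 3 (2.56 log units; beyond the scatter) shows.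

Compound 4 `O=C(CN1CCN(c2nnc(Cc3ccccc3)c3ccccc23)CC1)Nc1cc(C(F)(F)F)ccc1Cl` has not yet been measured. It differs from compound 2 in one place: 2-chloro-5-(trifluoromethyl)phenyl in place of 5-fluoro-2-methylphenyl on an amide-type nitrogen. Within the data shown here, only one measured step touches the same amide-type nitrogen, a 48-fold lower number from compound 1 to compound 3 (1.68 log units; beyond the scatter), and it was large. Among the measured compounds shown here, neither group in that step is the group entering in compound 4, so it shows only that a change at this place can move the number a great deal, not in which direction. The step of a 360-fold lower number from compound 2 to compound 3 (2.56 log units; beyond the scatter) changes another part of the molecule and does not bear directly on this change.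

The direction is therefore open, and a step of moderate size either way would not surprise. Compound 4 is expected to give about 80000 nM, within a range from 15000 nM to 300000 nM. This estimate means a step of a 2.1-fold lower number from compound 2 to compound 4 (0.33 log units; beyond the scatter).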

Compound 4, half-maximal inhibitory concentration: 66800 nM
Beside the measured number, compound 4's estimate is 1.2-fold (0.08 log units) above it, and the stated range covers the measured number.
By their numbers in this assay, from the lowest: compound 3; then compound 1; then compound 4; then compound 2.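

In this assay, putting 2-chloro-5-(trifluoromethyl)phenyl in place of 5-fluoro-2-methylphenyl on the amide-type nitrogen gives a 2.6-fold lower number from compound 2 to compound 4 (0.41 log units; beyond the scatter), so among the compounds with a plain phenyl on the chain, this position now has a measured direction: the group with 11 heavy atoms gives the lower number than the group with 8. The change is modest next to a 360-fold lower number from compound 2 to compound 3 (2.56 log units; beyond the scatter), and also next to a 48-fold lower number from compound 1 to compound 3 (1.68 log units; beyond the scatter), the earlier step at this nitrogen, which involved other aryl groups and a pyridin-4-yl in place of the phenyl. No measurement shown here offers an explanation for the step.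

On these data alone, whether the same swap would move a pyridin-4-yl compound by a similar amount remains open. So does the outcome with an aryl group on this nitrogen that carries a carboxylic acid or an amine.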